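From an Aryl Ring to Ethyl on the Ring Nitrogen

The compounds below may be only part of what the source reports. "The series", "measured", "known", "first", "only" and "open" are said of these compounds alone.

Compound 1 `COc1ccc(C)cc1N1C(=O)CSC1c1cccc(C(=O)NCCCCc2ccccc2)c1` gives 92% in a functional assay on MG-63 cells (Homo sapiens) for inhibition, read by CCK-8 assay, with a stated time of 72 h, tested at 1 uM; a lower number here means less inhibition, a higher number more inhibition at the concentration tested (going by the name of the read-out).
Compound 2 `O=C(NCCCCc1ccccc1)c1cccc(C2SCC(=O)N2c2ccccc2)c1` gives 89% in this assay.
Compound 3 `Cc1cccc(N2C(=O)CSC2c2cccc(C(=O)NCCCCc3ccccc3)c2)c1` gives 93% in this assay.

Compound 3 shows the highest of the three numbers, yet the steps of a number 1 percentage points higher from compound 1 to compound 3 (within the scatter) and a number 4 percentage points higher from compound 2 to compound 3 (within the scatter) both lie within the scatter, so no ordering among the three can be claimed. Compound 4 `CCN1C(=O)CSC1c1cccc(C(=O)NCCCCc2ccccc2)c1` differs from compound 3 by ethyl in place of 3-methylphenyl on an amide-type nitrogen in a ring. The measured steps, including a number 3 percentage points lower from compound 1 to compound 2 (within the scatter), only exchange substituents on that aromatic ring, and all stayed within the scatter; none removes the ring itself. They therefore offer no direct guide, and a somewhat lower number is expected, with wide uncertainty. The step of a number 15 percentage points lower from compound 3 to compound 4 (beyond the scatter) is the estimated change. Compound 4 is expected to give 78% in this assay, within 45% to 95%.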

Compound 4, a percentage reported as inhibition, at one concentration (the size of the read-out at that concentration, not a potency): 0%
Beside the measured number, compound 4's estimate is 78 percentage points above it; the measured number lies below the stated range.
By their numbers in this assay, from the lowest: compound 4; then compounds 2, 1 and 3 (each within the scatter of the next).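

In this assay the whole aryl ring on the amide-type nitrogen matters far more than the substituents on it: those substituent changes stayed within the scatter, whereas ethyl in its place brings large falls (a number 93 percentage points lower from compound 3 to compound 4 (beyond the scatter)), (a number 89 percentage points lower from compound 2 to compound 4 (beyond the scatter)) and (a number 92 percentage points lower from compound 1 to compound 4 (beyond the scatter)). At this position, 3-methylphenyl, phenyl and 2-methoxy-5-methylphenyl all go with high numbers, and ethyl goes with none. No measurement here explains the loss. Still open, going by these compounds, is whether an aromatic ring is required or a larger group of any kind would do, which a cyclohexyl ring or a butyl chain on that nitrogen could test.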